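A few compounds are considered here, and "the series" means these few. Any claim that something is new, unique, unknown or untested is made for them only; others in the source may bear on it.

Going by the values given here, compound 3 `CCCCc1ccc(C(=O)CC(SCC(=O)O)C(=O)O)cc1` gives 1920 nM in a functional assay on HeLa cells (Homo sapiens) for inhibition (a higher number here means a weaker inhibitor, a lower number a stronger inhibitor), the lowest of the three numbers measured so far; compound 1 `O=C(O)CSC(CC(=O)c1ccccc1)C(=O)O` gives 15000 nM and compound 2 `Cc1ccc(C(=O)CC(SCC(=O)O)C(=O)O)cc1` gives 17300 nM. Compound 4 `O=C(O)CSC(CC(=O)c1ccc(Br)cc1)C(=O)O` differs from compound 3 by bromo in place of butyl on an aromatic carbon. Among the compounds with values here, the steps that bear on this are a 7.8-fold lower number from compound 1 to compound 3 (0.89 log units; beyond the scatter) and a 1.2-fold higher number from compound 1 to compound 2 (0.06 log units; within the scatter), which show butyl on that aromatic carbon bringing a lower number while methyl there left the number within the scatter. Within the data shown here, removing the butyl is therefore expected to give back most of that gain, and bromo, a single heavy atom, has no measured precedent for recovering it. The expected step is a 4.2-fold higher number from compound 3 to compound 4 (0.62 log units; beyond the scatter). Compound 4 is thus estimated at 8000 nM, with a range from 3000 nM to 25000 nM.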

Compound 4, half-maximal inhibitory concentration: 9500 nM
For compound 4 the middle estimate is 1.2-fold (0.07 log units) below the measured one; low and high end bracket the measured number.
By their numbers in this assay, from the lowest: compound 3; then compounds 4, 1 and 2 (each within the scatter of the next).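

In this assay, replacing butyl with bromo on this aromatic carbon gives a 4.9-fold higher number from compound 3 to compound 4 (0.69 log units; beyond the scatter), so this single heavy atom does not keep the low number seen with butyl. Bromo also stays within the scatter of hydrogen and methyl at this place, as shown by a 1.6-fold lower number from compound 1 to compound 4 (0.20 log units; within the scatter) and a 1.8-fold lower number from compound 2 to compound 4 (0.26 log units; within the scatter), which leaves butyl as the only one of these four groups set apart. No measurement here explains this difference. From the compounds shown here alone, it remains open how a propyl group or a longer chain would behave on this carbon, and whether an amine there would give a number like that of butyl or like that of bromo.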